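This account rests on a few compounds, and the source may have more. Where it says the series, first, only, none or still open, it means among the compounds named here.

Compound 1 `CCCCCCCCCCCCCCCCOP(=O)(O)OCCSC(=S)N1CCCCCC1`: > 100000 nM, a limit rather than a number
Compound 2 `CCCCCCCCCCOP(=O)(O)OCCSC(=S)N1CCCC1`: 67000 nM
Compound 3 `CCCCCCCCCCOP(=O)(O)OCCSC(=S)N1CCN(C)CC1`: 29000 nM

These results come from a functional assay on MDA-MB-231 cells (Homo sapiens) for inhibition, read by MTT assay, with stated times of 18 h and 4 h; a lower number here means a stronger inhibitor, a higher number a weaker inhibitor. All three compounds are weak inhibitors. Compound 2 gives 67000 nM, the higher of the two true numbers, and the step of a 2.3-fold lower number from compound 2 to compound 3 (0.36 log units; beyond the scatter) leads to the only stronger result.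

Compound 4 `CCCCCCCCCCCCCCCCOP(=O)(O)OCCSC(=S)N1CCCC1` extends the chain of compound 2: hexyl in place of hydrogen on a saturated chain carbon, ten or more bonds along the chain from an oxygen on an unsaturated carbon. Within the data shown here, no measured step changes the chain alone. Among the measured compounds shown here, the one measured step, a 2.3-fold lower number from compound 2 to compound 3 (0.36 log units; beyond the scatter), is modest and changes a different part of the molecule, so it shows only how small a single change has been here. Compound 1 carries the same long chain as compound 4, with a different group on the thiocarbonyl carbon, and the limit of > 100000 nM in this assay, at which 1 of the 3 values shown sits, applies to it. This hints at weakness but cannot isolate the chain's contribution.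

The expected result is little change, perhaps slightly weaker, with an estimated 1.2-fold higher number from compound 2 to compound 4 (0.08 log units; within the scatter). For compound 4 the estimated value is 80000 nM, with an expected range of 30000 nM to 200000 nM.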

Compound 4, half-maximal inhibitory concentration: 69000 nM
The estimate for compound 4 lay 1.2-fold (0.06 log units) above the measured number; the range from low to high includes it.
By their numbers in this assay, from the lowest: compound 3; then compounds 2 and 4 (each within the scatter of the next). At a limit, above all of these: compound 1.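

Adding hexyl to the chain gives a 1.0-fold higher number from compound 2 to compound 4 (0.01 log units; within the scatter) and so leaves no change that can be told from scatter, the first reading of this chain extension on its own. Compound 4 keeps the long chain of compound 1 yet gives a true number, and the ring change on the thiocarbonyl carbon gives an at least 1.4-fold lower number from compound 1 to compound 4 (0.16 log units; that floor lies within the scatter) with no difference that can be claimed from that floor. Compound 1 itself stands at a limit, not a number: the limit of > 100000 nM in this assay, at which 1 of the 4 values shown sits.

Still open, as far as these compounds go, is whether the 4-methylpiperazin-1-yl group, which gave the only stronger result on the shorter chain, would do the same on the chain of compound 4. Also open, from the compounds shown here alone, is whether a much shorter chain, or a chain carrying an amine, would move the number at all.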